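The source may hold more compounds than are shown below. What is called first, only, known or untested is meant among the compounds shown, and "the series" means these compounds.

Measured compounds:
- compound 1 `Cc1cc(C(=O)Nc2ccc(F)cc2)nn1-c1cccc(C(F)(F)F)c1` — 800 nM
- compound 2 `Cc1cc(C(=O)Nc2cc(Cl)cc(Cl)c2)nn1-c1ccc(C(F)(F)F)cc1` — > 1000 nM

In an assay on HEK293 cells for binding affinity to Neuropeptide Y receptor type 5 (Homo sapiens), read by radioligand binding (a lower number here means a stronger inhibitor, a higher number a weaker inhibitor), compound 1 gives 800 nM. Compound 2 gives > 1000 nM, which is a limit of the assay and not a number. Compound 1 thus carries the only number shown in this assay; the one other value is a limit, see (the limit of > 1000 nM in this assay, at which 1 of the 2 values shown sits). For the measured compounds named here, compound 2 differs from compound 1 in more than one place, so no single step can be read between them, and the two values show only that compound 1 has a number where compound 2 has a limit.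

Compound 3 `Cc1cc(C(=O)Nc2cccc(Br)c2)nn1-c1cccc(C(F)(F)F)c1` is not yet measured. It differs from compound 1 by 3-bromophenyl in place of 4-fluorophenyl on an amide-type nitrogen. Going by the values given here, no step between measured compounds of this kind is available, so the expectation rests on compound 1 alone. In this assay a step from compound 1 to compound 3 that stays within the usual scatter is expected, with no clear direction. Compound 3 is therefore estimated at 700 nM, with a range from 250 nM to 2000 nM. The step of a 1.1-fold lower number from compound 1 to compound 3 (0.06 log units; within the scatter) is the expected outcome, with a fair chance that only a limit is reported.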

Compound 3, half-maximal inhibitory concentration: 359 nM
Beside the measured number, compound 3's estimate is 1.9-fold (0.29 log units) above it; the measured number falls inside the stated range.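

In this assay the series now has its first readable step, at the aryl group on the amide-type nitrogen: 3-bromophenyl in place of 4-fluorophenyl gives a 2.2-fold lower number from compound 1 to compound 3 (0.35 log units; beyond the scatter), a modest change. The two groups match in heavy-atom count and both hold one six-membered aromatic ring of carbon only, so the value at this position responds to a swap that leaves those counts unchanged, but the identity of the halogen and its place on the ring change together in this one step and cannot be separated. Nothing measured here bears on the reason for the step.

Compound 2 carries a limit and not a number, and it differs from compound 1 and from compound 3 in more than one place, so no step to it can be read: the limit of > 1000 nM in this assay, at which 1 of the 3 values shown sits.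

Still open, as far as these compounds go, is whether the halogen matters at all at this position, since a methoxy group, a nitrile or an amine in place of the bromine on the phenyl ring could move the number either way, and whether a second step of this kind would hold on the same core.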